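This account rests on a few compounds, and the source may have more. Where it says the series, first, only, none or still open, it means among the compounds named here.

In a functional assay on Vero cells (Chlorocebus sabaeus) for cytotoxicity (a lower number here means a stronger inhibitor, a higher number a weaker inhibitor), compound 1 `Nc1ccn([C@H]2C=C(F)[C@H](CO)O2)c(=O)n1` gives > 100000 nM, which is a limit of the assay and not a number. Compound 2 `Nc1nc(=O)n([C@@H]2C=C(F)[C@H](CO)O2)cc1F` gives > 100000 nM, which is also a limit. Compound 2 thus has no numerical position, and the evidence so far is the limit of > 100000 nM in this assay, at which 2 of the 2 values shown sit. Going by the values given here, no measured step is available.

Next is compound 3 `Nc1nc(=O)n([C@H]2C=C(F)[C@H](CO)O2)cc1F`, related to compound 2 by the two compounds have the same atoms and bonds and differ only in configuration as drawn: 1 of 2 stereo elements differ; a stereocentre at a saturated ring carbon is drawn S in compound 2 and R in compound 3: a stereocentre at a saturated ring carbon is drawn S in compound 2 and R in compound 3. No change beyond the scatter is expected in this assay, and a reading at the limit is the likeliest outcome. This expectation rests on compound 2 with its limit > 100000 nM. The expected step is a number no higher from compound 2 to compound 3 (the limit leaves the size open). For compound 3 the estimated value is 100000 nM, with an expected range of 40000 nM to 200000 nM.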

Compound 3, half-maximal inhibitory concentration: > 100000 nM
Compound 3: a limit, no number (the forecaster's own chance of this, stated with the estimate: 85%); the middle value lies on the limit itself.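

Compound 3 reads as a limit, like compound 1 and compound 2, so neither step, from compound 2 or from compound 1 to compound 3, can be read. The compounds shown leave open whether configuration or fluoro in place of hydrogen changes the read-out in this assay.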